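This account rests on a few compounds, and the source may have more. Where it says the series, first, only, none or still open, it means among the compounds named here.

Measured in a functional assay on DU-145 cells (Homo sapiens) for inhibition, read by trypan blue exclusion, with a stated time of 96 h; a lower number here means a stronger inhibitor of growth, a higher number a weaker inhibitor of growth:
Compound 1 `Cc1ccc(S/C(=C/c2ccc(Br)cc2)C(=O)c2ccc(Cl)cc2)cc1`: 25000 nM
Compound 2 `O=C(/C(=C\c1ccc(O)c([N+](=O)[O-])c1)SCc1ccc(Br)cc1)c1c(F)c(F)c(F)c(F)c1F`: 10000 nM

Compound 1 holds the higher of the two numbers, and compound 2 stands lower by a margin beyond the usual scatter. Compound 3 `Cc1ccc(S/C(=C/c2ccc(N(C)C)cc2)C(=O)c2ccc(Cl)cc2)cc1` keeps the core of compound 1 and differs in one place: dimethylamino in place of bromo on an aromatic carbon. This puts dimethylamino in place of bromo on an aromatic carbon. For the measured compounds named here, no measured pair shows this change, so the expectation is loose. A modest move toward a lower number is expected in this assay, perhaps not beyond the scatter, as the estimated 1.8-fold lower number from compound 1 to compound 3 (0.25 log units; within the scatter). For compound 3 the estimated value is 14000 nM, with an expected range of 4000 nM to 50000 nM.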

Compound 3, concentration for 50% growth inhibition: > 100000 nM
Compound 3: no number, only a limit; the forecaster's own chance of this, stated with the estimate: 10%; at least 7.1-fold (0.85 log units) between middle value and limit.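

In this assay, this aromatic carbon proves sensitive to what it carries: dimethylamino in place of bromo gives an at least 4.0-fold higher number from compound 1 to compound 3 (0.60 log units; beyond the scatter), so growth inhibition weakens with this change. Compound 3 gives > 100000 nM, which is a limit of the assay and not a number. The step therefore has a minimum size but no known full size.

The compounds shown leave open whether a primary amine, a methoxy group or chloro at this place would stay close to bromo. This single pair also cannot separate the nitrogen from the larger group that carries it.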